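The compounds below may be only part of what the source reports. "The series", "measured", "known", "first", "only" and "open" are said of these compounds alone.

Measured in a functional assay on HT-29 cells (Homo sapiens) for inhibition, read by CCK-8 assay, with a stated time of 24 h; a higher number here means a weaker inhibitor, a lower number a stronger inhibitor:
compound 1 `O=C1Nc2ccccc2/C1=C/c1ccc(-c2cn(-c3ccc(Cl)cc3)nn2)cc1` gives 14000 nM
compound 2 `N#Cc1cccc(-n2cc(-c3ccc(/C=C4\C(=O)Nc5ccccc54)cc3)nn2)c1` gives > 20000 nM (a limit of the assay)
compound 3 `O=C1Nc2ccc(F)cc2C1=Cc1ccc(-c2cn(-c3ccccc3)nn2)cc1` gives 8120 nM

Within the data shown here, only two of these three values are actual numbers. Compound 3, at 8120 nM, and compound 1, at 14000 nM, lie within the scatter of each other, so neither can be ranked ahead of the other. The value of compound 2 is a limit.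

Compound 4 `N#Cc1ccc(-n2cc(-c3ccc(C=C4C(=O)Nc5ccc(F)cc54)cc3)nn2)cc1` is compound 3 with one change, phenyl to 4-cyanophenyl: cyano in place of hydrogen on an aromatic carbon, para to a large group (cyano in place of hydrogen on an aromatic carbon). Among the measured compounds shown here, one measured step bears on this, and only indirectly: an at least 1.4-fold higher number from compound 1 to compound 2 (0.15 log units; that floor lies within the scatter). It also places a cyano group on the aryl ring, but at a different position, it removes a chlorine, and it sits on the core of compound 1 rather than that of compound 3. It rests on (the limit of > 20000 nM in this assay, at which 1 of the 3 values shown sits), so its true size is open and only its floor is known, which lies within the scatter.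

That gives weak grounds for expecting a small rise in the number in this assay, and none clearly beyond the scatter. The expected change is a 1.4-fold higher number from compound 3 to compound 4 (0.13 log units; within the scatter), an estimate that carries wide uncertainty. A reading at the limit of the assay would not be surprising. For compound 4 the estimate is 11000 nM, with an expected range from 4500 nM to 20000 nM.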

Compound 4, half-maximal inhibitory concentration: 20000 nM
Estimate against measurement, compound 4: 1.8-fold (0.26 log units) below; the range from low to high includes it.
By their numbers in this assay, from the lowest: compounds 3, 1 and 4 (each within the scatter of the next, the first and the last beyond it).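

Cyano in place of hydrogen, para to a large group, now has a measured effect on one unchanged core in this assay: a 2.5-fold higher number from compound 3 to compound 4 (0.39 log units; beyond the scatter). Among these compounds, this is the first step on this ring that lies beyond the scatter and changes a single place, and it runs towards a weaker inhibitor, though only by a modest amount, whereas the earlier step on the aryl ring also removed a chlorine and gave only a floor. The number for compound 4 falls at the same figure as the limit of compound 2, which leaves this series little room for any further rise to be read as a number: the limit of > 20000 nM in this assay, at which 1 of the 4 values shown sits.

On these data alone, what an amine or a carboxylic acid in the same place on the phenyl ring would give remains open, as does whether cyano in this place has a similar effect on the core of compound 1. The part played by the fluorine on the core of compound 3 is also unresolved: compound 1 and compound 3 differ in more than one place.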